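Replacing an aryloxy group with a benzylamino group

The source may hold more compounds than are shown below. What is called first, only, known or untested is meant among the compounds shown, and "the series" means these compounds.

The series shares one core. In a functional assay on SK-MEL-2 cells (Homo sapiens) for inhibition, read by sulforhodamine B assay, with a stated time of 48 h (a lower number here means a stronger inhibitor of growth, a higher number a weaker inhibitor of growth), compound 1, `Nc1cc(N)c2nc(-c3ccccc3)c(Oc3ccc(Cl)c(Cl)c3)nc2c1`, gives 23400 nM, the lowest of the two numbers measured, while compound 2, `CCOC(=O)[C@H](CCC(=O)O)NC(=O)c1ccc(Sc2nc3cc(N)cc(N)c3nc2-c2ccccc2)cc1`, gives 63100 nM, a gap beyond the scatter. For compound 3, `COc1cc(CNc2nc3cc(N)cc(N)c3nc2-c2ccccc2)cc(OC)c1OC`, this assay gives only a limit, < 50200 nM, at which one of the three values sits, as in the limit of < 50200 nM in this assay, at which 1 of the 3 values shown sits. Compound 4, `Nc1cc(N)c2nc(-c3ccccc3)c(NCc3ccc(F)cc3)nc2c1`, is not yet measured; it carries (4-fluorobenzyl)amino in place of 3,4-dichlorophenoxy on an aromatic carbon. Within the data shown here, no measured step links these groups, so the writer expects no change beyond the scatter, a step of about a 1.1-fold lower number from compound 1 to compound 4 (0.03 log units; within the scatter). Compound 4 is therefore estimated at 22000 nM, between 6000 nM and 80000 nM.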

Compound 4, concentration for total growth inhibition: < 100000 nM
Compound 4 was reported as a limit; the forecaster's own chance of this, stated with the estimate: 15%; the middle value does not contradict the limit.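

In this assay, among these compounds, compound 4 gives < 100000 nM as a limit and not a number, so no step from compound 1 to compound 4 can be read. The compounds shown leave open whether (4-fluorobenzyl)amino in place of 3,4-dichlorophenoxy changes growth inhibition at all.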